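Swapping the amide aryl for a tert-butyl isoxazole

This account rests on a few compounds, and the source may have more. Where it says the series, first, only, none or still open, it means among the compounds named here.

Compound 1: `CCc1ccc(C(=O)Nc2cccc(NC(=O)COc3ccc4c(=O)ccoc4c3)c2)cc1` — 235 nM
Compound 2: `CC(C)(C)c1ccc(C(=O)Nc2cccc(NC(=O)COc3ccc4c(=O)ccoc4c3)c2)cc1` — 165 nM
Compound 3: `Cc1cc(C(=O)Nc2cccc(NC(=O)COc3ccc4c(=O)ccoc4c3)c2)ccc1C(F)(F)F` — 460 nM

Of the compounds shown here, three sharing one core have been measured in an assay on isolated protein for inhibition of Rho-associated protein kinase 1 (Homo sapiens), read by scintillation counting, radiometric assay and 33P incorporation, with a stated time of 40 min, in the presence of a further agent that is not named here; a lower number here means a stronger inhibitor, a higher number a weaker inhibitor. Compound 3 gives the highest of the three numbers in this assay: its nearest neighbour is compound 1, with a 2.0-fold higher number from compound 1 to compound 3 (0.29 log units; within the scatter), and its furthest is compound 2, with a 2.8-fold higher number from compound 2 to compound 3 (0.45 log units; beyond the scatter). The step from compound 1 to compound 2, a 1.4-fold lower number from compound 1 to compound 2 (0.15 log units; within the scatter), lies within the scatter.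

Compound 4, `CC(C)(C)c1cc(C(=O)Nc2cccc(NC(=O)COc3ccc4c(=O)ccoc4c3)c2)no1`, differs from compound 3 in one place: a group of 9 heavy atoms (7 carbon, 1 nitrogen, 1 oxygen; one five-membered aromatic ring with 2 hetero atoms) in place of a group of 11 heavy atoms (8 carbon, 3 fluorine; one six-membered aromatic ring of carbon only), on a carbonyl carbon. The tert-butyl group thereby returns, now carried on a five-membered ring with two hetero atoms rather than on the six-membered carbon ring of compound 2. Among the measured compounds shown here, the step that bears most directly on this change is the one from compound 2 to compound 3, a 2.8-fold higher number from compound 2 to compound 3 (0.45 log units; beyond the scatter), which shows that replacing the tert-butyl-bearing ring with the trifluoromethyl-bearing one raised the number modestly. The reverse direction is therefore expected to lower it by a comparable, modest amount, with the ring change itself adding uncertainty. Compound 4 is accordingly expected to give 170 nM, in the range 70 nM to 420 nM, corresponding to an expected step of a 2.7-fold lower number from compound 3 to compound 4 (0.43 log units; beyond the scatter).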

Compound 4, half-maximal inhibitory concentration: 101 nM
Compound 4: the middle estimate sits 1.7-fold (0.23 log units) above what was measured, and the stated range covers the measured number.
By their numbers in this assay, from the lowest: compounds 4, 2, 1 and 3 (each within the scatter of the next, the first and the last beyond it).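

On the carbonyl carbon whose other neighbour is the amide-type nitrogen, a five-membered aromatic ring with two hetero atoms can take the place of a six-membered carbon ring without a clear change in this assay: 5-(tert-butyl)-1,2-oxazol-3-yl in place of 4-(tert-butyl)phenyl gives only a small step (a 1.6-fold lower number from compound 2 to compound 4 (0.21 log units; within the scatter)). Compound 2 and compound 4 therefore cannot be told apart, and among these compounds this position does not depend on the six-membered carbon ring. The same group does separate from the other two aryl groups, by a modest step against 4-ethylphenyl (a 2.3-fold lower number from compound 1 to compound 4 (0.37 log units; beyond the scatter)) and by the largest step seen among the four compounds against the group of compound 3 (a 4.6-fold lower number from compound 3 to compound 4 (0.66 log units; beyond the scatter)).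

No accompanying measurement bears on why the number moves with this change. Whether the 1,2-oxazole needs its tert-butyl group remains open, and the compounds shown do not tell how a methyl group, an amine or a carboxylic acid in that place on the ring would read in this assay.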